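The source may hold more compounds than are shown below. What is called first, only, known or untested is meant among the compounds shown, and "the series" means these compounds.

Three compounds share one core. In a functional assay on DU-145 cells (Homo sapiens) for cytotoxicity, read by MTT assay, with a stated time of 48 h (a lower number here means a stronger inhibitor, a higher number a weaker inhibitor), compound 1 `c1ccc(-c2nc(-c3c[nH]c4ccccc34)co2)cc1` gives 167000 nM. In this assay compound 2 `c1ccc2c(-c3coc(-c4ccncc4)n3)c[nH]c2c1` gives 178000 nM, and compound 3 `Clc1ccc(-c2nc(-c3c[nH]c4ccccc34)co2)cc1` gives 206000 nM, a number that sits alongside the other two within the scatter, as the steps of a 1.2-fold higher number from compound 1 to compound 3 (0.09 log units; within the scatter) and a 1.2-fold higher number from compound 2 to compound 3 (0.06 log units; within the scatter) show. Compound 4 `c1ccc2c(-c3coc(C4CCNCC4)n3)c[nH]c2c1` has not yet been measured and differs from compound 3 in one place: piperidin-4-yl in place of 4-chlorophenyl on an aromatic carbon. The earlier changes at this same position, a 1.1-fold higher number from compound 1 to compound 2 (0.03 log units; within the scatter) and a 1.2-fold higher number from compound 2 to compound 3 (0.06 log units; within the scatter), both stayed within the scatter. On that basis no step beyond the scatter is expected here either, and the expected step is a 1.1-fold lower number from compound 3 to compound 4 (0.04 log units; within the scatter). In this assay compound 4 is therefore estimated at 190000 nM, with a range from 80000 nM to 450000 nM.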

Compound 4, half-maximal inhibitory concentration: 381000 nM
Estimate against measurement, compound 4: 2.0-fold (0.30 log units) below; low and high end bracket the measured number.
By their numbers in this assay, from the lowest: compounds 1, 2, 3 and 4 (each within the scatter of the next, the first and the last beyond it).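

In this assay, among these compounds, two steps at this position now pass the scatter, though only modestly: a 2.1-fold higher number from compound 2 to compound 4 (0.33 log units; beyond the scatter) and a 2.3-fold higher number from compound 1 to compound 4 (0.36 log units; beyond the scatter) are the first to do so, while a 1.8-fold higher number from compound 3 to compound 4 (0.27 log units; within the scatter) stays within it. A non-aromatic ring with a hydrogen-bond donor, in place of phenyl or pyridin-4-yl, therefore gives a slightly higher number, so this position is not wholly indifferent to its group. Nothing available explains this shift. The compounds shown leave open whether the ring or its nitrogen matters, which a cyclohexyl ring or an open-chain amine at this position could help separate.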